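This account rests on a few compounds, and the source may have more. Where it says the series, first, only, none or still open, it means among the compounds named here.

Within the data shown here, compound 1 `CCC(=O)N1CC2(CC(NC(=O)c3cc(-c4ccccc4)no3)C2)C1` stands highest of the three compounds measured so far in an ADME assay on microsomes from liver (Macaca mulatta) for metabolic stability, with a stated time of 0.5 h, tested at 0.5 mg/mL; a lower number here means that less of the compound is left, a higher number that more of the compound is left. In this assay compound 1 gives 69%. Compound 2 `CC(=O)N1CC(CNC(=O)c2cc(-c3ccccc3)no2)C1` gives 17% in this assay, a number beyond the scatter below that of compound 1, and compound 3 `CN(C)C(=O)CNC(=O)c1cc(-c2ccc(F)cc2)no1` gives 11% in this assay, further below still. Among the measured compounds shown here, no pair of measured compounds differs in only one place, so the set offers no direct measure of what a single change does.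

Compound 4 `CC(C)C(=O)N1CC2(CC(NC(=O)c3cc(-c4ccccc4)no3)C2)C1` is the one not yet measured. It differs from compound 1 in one place: methyl in place of hydrogen on a saturated chain carbon bound to a carbonyl carbon and a saturated chain carbon. Read one bond further out, the same difference turns ethyl into isopropyl and propanoyl into isopropylcarbonyl. For the measured compounds named here, nothing among the measured compounds shows the effect of such a change, so the expectation rests on compound 1 alone, whose 69% is the starting point. The step from compound 1 to compound 4 in this assay is expected to be small, a number 1 percentage points higher from compound 1 to compound 4 (within the scatter), and probably not beyond the scatter in either direction. Compound 4 is therefore estimated to give 70% in this assay, within a range from 50% to 85%.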

Compound 4, percent of the compound remaining: 55%
For compound 4 the middle estimate is 15 percentage points above the measured one; the measured number falls inside the stated range.
By their numbers in this assay, from the lowest: compounds 3 and 2 (each within the scatter of the next); then compound 4; then compound 1.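

The set now holds its first direct reading of a single change: in this assay, methyl in place of hydrogen on a saturated chain carbon bound to a carbonyl carbon and a saturated chain carbon, which turns propanoyl into isopropylcarbonyl, gives a number 14 percentage points lower from compound 1 to compound 4 (beyond the scatter). This shows that the read-out responds to one added carbon at this place while the rest of the structure stays the same, and that the response to this change is downward, although a single step gives a direction for this one pair and no trend. Nothing at hand accounts for the drop, and no measurement explains why the isopropyl group gives the lower number.

Going by these compounds, whether a longer chain such as butanoyl, a cyclopropyl ring, or an ether or an amine carried on the same carbonyl would stay close to compound 1 or fall further remains open. Also open, on these data alone, is whether ethyl to isopropyl would give a step of similar size on a different core, since this change is seen on only one.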